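Mirror-image pair on the shared core: compound 1 to compound 4

This account rests on a few compounds, and the source may have more. Where it says the series, first, only, none or still open, it means among the compounds named here.

Measured so far:
compound 1 `Cc1cc(C)c(CN2CCc3c(Cl)cc([C@H](CO)[C@H]4CCOC4)c(Cl)c3C2=O)c(=O)[nH]1` — 10 nM
compound 2 `COC(c1cc(Cl)c2c(c1Cl)C(=O)N(Cc1c(C)cc(C)[nH]c1=O)CC2)C1CCOC1` — 1100 nM; 494 nM; 47 nM; 7 nM (4 entries)
compound 3 `Cc1cc(C)c(CN2CCc3c(Cl)cc(C(CO)c4ccon4)c(Cl)c3C2=O)c(=O)[nH]1` — 7960 nM; 273 nM (2 entries)

For the measured compounds named here, in an assay on cells for inhibition of histone-lysine N-methyltransferase EZH2 (Homo sapiens), read by ELISA, with a stated time of 72 h (on this read-out lower numbers stand for stronger inhibition and higher numbers for weaker inhibition), compound 1 gives 10 nM and is the one compound of the three with a single number; compound 2 and compound 3 each carry several entries spread over a wide band, the several entries of compound 2 in this assay, 1100 nM; 494 nM; 47 nM; 7 nM (4 entries) and (the several entries of compound 3 in this assay, 7960 nM; 273 nM (2 entries)).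

Compound 4 `Cc1cc(C)c(CN2CCc3c(Cl)cc([C@@H](CO)[C@@H]4CCOC4)c(Cl)c3C2=O)c(=O)[nH]1` is not yet measured. It differs from compound 1 as follows: the two compounds have the same atoms and bonds and differ only in configuration as drawn: 2 of 2 stereo elements differ (all stereocentres are inverted: mirror images); a stereocentre at a saturated chain carbon is drawn R in compound 1 and S in compound 4; a stereocentre at a saturated ring carbon is drawn R in compound 1 and S in compound 4. Nothing new enters and nothing leaves; the two compounds have the same atoms and bonds and differ only in configuration as drawn, all stereocentres inverted, mirror images.

Going by the values given here, no step between measured compounds is available for this change. The spread within the entries of compound 2, (the several entries of compound 2 in this assay, 1100 nM; 494 nM; 47 nM; 7 nM (4 entries)), and of compound 3, (the several entries of compound 3 in this assay, 7960 nM; 273 nM (2 entries)), is well beyond the scatter of repeated measurement, so configuration on this core is taken to matter and the mirror image of compound 1 is expected to be weaker rather than within the scatter. For compound 4 the expected value in this assay is 500 nM, with a range from 50 nM to 5000 nM, which means an expected step of a 50-fold higher number from compound 1 to compound 4 (1.70 log units; beyond the scatter) from compound 1 to compound 4.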

Compound 4, half-maximal inhibitory concentration: 2910 nM
Compound 4: middle estimate off by 5.8-fold (0.76 log units), on the low side; the range from low to high includes it.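

Inverting both stereocentres on the shared core gives a 290-fold higher number from compound 1 to compound 4 (2.46 log units; beyond the scatter) in this assay, so this position is sensitive to configuration, with the drawn R,R form of compound 1 carrying the lower number. The whole step can be assigned to configuration, because nothing enters or leaves: the fact that compounds 1 and 4 differ only in the configuration as drawn. The earlier compounds shown here could not show this, as they are drawn without configuration and their wide spreads tie no number to any one form: the several entries of compound 2 in this assay, 1100 nM; 494 nM; 47 nM; 7 nM (4 entries).

The compounds shown contain no pair in which only the stereocentre at the saturated chain carbon or only the one at the saturated ring carbon is inverted, so the share of each centre in the step remains open. Also open, going by these compounds, is whether the same dependence on configuration holds when a carboxylic acid or an amine takes the place of the hydroxyl group on the chain.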